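Replacing the 1,3-benzoxazol-2-yl group of compound 1

The source may report more compounds than this note shows. Statements on the series, on what has been measured and on what is new or still open speak of the compounds shown alone.

Among the measured compounds shown here, in a functional assay on A549 cells (Homo sapiens) for antiproliferative activity, read by MTT assay, with a stated time of 48 h (a higher number here means a weaker inhibitor, a lower number a stronger inhibitor), compound 1 `CN(C)CCCn1c(N)c(-c2nc3ccccc3o2)c2nc(C#N)c(C#N)nc21` gives 7170 nM and compound 2 `N#Cc1nc2c(-c3nc4ccccc4o3)c(N)n(CCCN3CCCCC3)c2nc1C#N` gives 8670 nM, which places compound 1 level with the only other measured compound. For the measured compounds named here, the one measured step, a 1.2-fold higher number from compound 1 to compound 2 (0.08 log units; within the scatter), concerns the chain, not the group changed here. Compound 3 `CN(C)CCCn1c(N)c(-c2nc3ccccc3n2C)c2nc(C#N)c(C#N)nc21` differs from compound 1 by 1-methyl-1H-benzimidazol-2-yl in place of 1,3-benzoxazol-2-yl on an aromatic carbon, on an aromatic carbon next to the ring atom that bears an amino group. Going by the values given here, no measured step touches this place, so the expectation rests on compound 1 at 7170 nM, with no step beyond the scatter foreseen. The expected result is a 1.2-fold lower number from compound 1 to compound 3 (0.08 log units; within the scatter). For compound 3 the estimated value is 6000 nM, within an expected range of 1800 nM to 20000 nM.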

Compound 3, half-maximal inhibitory concentration: 11700 nM
Compound 3: middle estimate off by 2.0-fold (0.29 log units), on the low side; measured number inside the range.
By their numbers in this assay, from the lowest: compounds 1, 2 and 3 (each within the scatter of the next).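

In this assay, this first measured change on the aromatic carbon gives a 1.6-fold higher number from compound 1 to compound 3 (0.21 log units; within the scatter), so 1-methyl-1H-benzimidazol-2-yl and 1,3-benzoxazol-2-yl cannot be told apart here. The position therefore accepts a group with one more heavy atom, with nitrogen bearing a methyl group in place of the ring oxygen, without a step beyond the scatter. No supporting measurement bears on this result. Open, going by these compounds, is how a 1,3-benzothiazol-2-yl or an unsubstituted 1H-benzimidazol-2-yl group would read in this place. Also open, on these data alone, is whether 1-methyl-1H-benzimidazol-2-yl would read alike with piperidin-1-yl in place of dimethylamino on the chain.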